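Hydrazone series: methoxy for fluoro, compound 2 to compound 4

The source may report more compounds than this note shows. Statements on the series, on what has been measured and on what is new or still open speak of the compounds shown alone.

Measured compounds in a functional assay on the whole organism (strain Wistar) for inhibition, with Rattus norvegicus as the target, read by paw edema, with a stated time of 2 h, at a dose of 10 mg/kg by the intraperitoneal route; on this read-out higher numbers stand for more inhibition at the one dose given (going by the name of the read-out) and lower numbers for less inhibition:
- compound 1 `O=C(N/N=C/c1ccccc1)c1cccnc1Nc1cccc(C(F)(F)F)c1`: 36.8%
- compound 2 `O=C(N/N=C/c1ccc(F)cc1)c1cccnc1Nc1cccc(C(F)(F)F)c1`: 41.2%
- compound 3 `O=C(N/N=C/c1ccc(Cl)cc1)c1cccnc1Nc1cccc(C(F)(F)F)c1`: 52.8%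

Compound 2 stands second highest of the three numbers. Its nearest neighbour is compound 1, the step of a number 4.4 percentage points higher from compound 1 to compound 2 (within the scatter) being within the scatter; its furthest is compound 3, where the step of a number 11.6 percentage points higher from compound 2 to compound 3 (beyond the scatter) lies beyond the scatter. The step of a number 16 percentage points higher from compound 1 to compound 3 (beyond the scatter) is of the same modest size and direction.

The unmeasured compound 4 `COc1ccc(/C=N/NC(=O)c2cccnc2Nc2cccc(C(F)(F)F)c2)cc1` differs from compound 2 in one place: methoxy in place of fluoro on an aromatic carbon.

Among the measured compounds shown here, the steps that bear on this change are those at the same place on the same ring: the fluoro for hydrogen step, which changed nothing beyond the scatter, and the two chloro steps, which gave modest rises. For the measured compounds named here, no methoxy analogue has been measured in this assay, so the direction for compound 4 rests only on the observation that replacing the substituent at this place has so far moved the read-out by no more than a modest amount. A step of the order of a number 3.8 percentage points higher from compound 2 to compound 4 (within the scatter) is expected, most likely within the scatter of compound 2, with a modest rise not excluded.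

Compound 4 is therefore estimated at 45%, with a range from 33% to 58%.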

Compound 4, a percentage reported as inhibition, in the whole organism at one dose (the size of the read-out at that dose, not a potency): 42.4%
Beside the measured number, compound 4's estimate is 2.6 percentage points above it, and the stated range covers the measured number.
By their numbers in this assay, from the lowest: compounds 1, 2 and 4 (each within the scatter of the next); then compound 3.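

In this assay the change from 4-fluorophenyl to 4-methoxyphenyl brings in a hydrogen-bond acceptor that fluoro lacks, yet it gives a number 1.2 percentage points higher from compound 2 to compound 4 (within the scatter) and the comparison with the unsubstituted ring gives a number 5.6 percentage points higher from compound 1 to compound 4 (within the scatter) so hydrogen, fluoro and methoxy at this place cannot be told apart on this read-out. The comparison with chloro gives a number 10.4 percentage points lower from compound 3 to compound 4 (beyond the scatter) so compound 3 is now set apart by steps beyond the scatter from all three other compounds, and the rise seen with chloro is not shared by a larger group at the same place. Nothing at hand offers an explanation for why chloro alone stands apart at this position.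

The compounds shown leave open whether bromo or a dimethylamino group at this place would follow chloro or stay with hydrogen, fluoro and methoxy. Every compound shown also keeps the trifluoromethyl group of the shared core, and whether the chloro step holds when that group is replaced by a nitrile or a carboxylic acid remains open too.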